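The compounds below may be only part of what the source reports. "The series", "measured", "known", "first", "only" and "open" are said of these compounds alone.

Measured compounds:
- compound 1 `ClCc1ccc(Cn2cnc3c(Cl)ncnc32)cc1`, in a functional assay on RXF 393 cells (Homo sapiens) for cytotoxicity, read by sulforhodamine B assay, with a stated time of 48 h (on this read-out higher numbers stand for lower toxicity in this test and lower numbers for higher toxicity in this test), compound 1 gives > 100000 nM, a limit of the assay.
- compound 2 `ClCc1ccccc1Cn1cnc2ncnc(Cl)c21`, in this assay compound 2 gives > 100000 nM, also a limit of the assay.

Among the compounds with values here, compound 2 thus stands only at a limit, with no number of its own; the one further value shown, that of compound 1, is a limit as well (the limit of > 100000 nM in this assay, at which 2 of the 2 values shown sit). Within the data shown here, no step between two measured compounds is available.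

Compound 3 `ClCc1ccccc1Cn1cnc2nc(Cl)nc(Cl)c21` differs from compound 2 by chloro in place of hydrogen on an aromatic carbon, on an aromatic carbon of a six-membered aromatic ring with two nitrogen, between two ring nitrogen atoms, meta to a chloro group.

With both known values sitting at the limit, no step beyond the scatter in this assay is expected from the change; the expected step of a number no higher from compound 2 to compound 3 (the limit leaves the size open) is taken as none. Compound 3 is accordingly estimated at 100000 nM, with a range of 30000 nM to 300000 nM, and most likely again reported only as a limit.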

Compound 3, concentration lethal to 50% of the cells: 6450 nM
Estimate against measurement, compound 3: 16-fold (1.19 log units) above; the measured number lies below the stated range.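

In this assay, the position between two ring nitrogen atoms proves responsive: chloro in place of hydrogen on an aromatic carbon gives an at least 15-fold lower number from compound 2 to compound 3 (1.19 log units; beyond the scatter). A single added chlorine there thus moves the read-out towards higher toxicity in this test, which compound 1 and compound 2 could not show while both stayed at a limit. The step gives only a lower bound on the size of the change, since its starting value is a limit and not a number: the limit of > 100000 nM in this assay, at which 2 of the 3 values shown sit.

The compounds shown leave open whether the step is specific to chloro, or whether an amine or a methoxy group at the same position would also lower the number. They also leave open whether the same change on the core of compound 1 would give a comparable step.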